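Trimming the branched chain on a cyanoguanidine

A few compounds are considered here, and "the series" means these few. Any claim that something is new, unique, unknown or untested is made for them only; others in the source may bear on it.

Compound 2 `CC(C)(C)/N=C(\NC#N)Nc1ccc(C#N)cc1` is weaker of the two measured compounds: in a functional assay (aorta) for inhibition, with Rattus norvegicus as the target (on this read-out lower numbers stand for stronger inhibition and higher numbers for weaker inhibition), compound 2 gives 530 nM, while compound 1 `CC(/N=C(\NC#N)Nc1cccc(C#N)c1)C(C)(C)C` gives 190 nM, a gap that lies beyond the usual scatter. Compound 3 `C/N=C(\NC#N)Nc1ccc(C#N)cc1` is the next step, with methyl in place of tert-butyl on a double-bonded nitrogen. Among the compounds with values here, no measured pair shows this change, so the expectation rests only on the two values above. The step from tert-butyl to methyl is expected to weaken inhibition further by a 2.8-fold higher number from compound 2 to compound 3 (0.45 log units; beyond the scatter). Compound 3 is therefore estimated at 1500 nM, between 400 nM and 6000 nM.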

Compound 3, half-maximal inhibitory concentration: 130000 nM
The estimate for compound 3 lay 87-fold (1.94 log units) below the measured number; measured number above the stated range.
By their numbers in this assay, from the lowest: compound 1; then compound 2; then compound 3.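

In this assay, methyl in place of tert-butyl on a double-bonded nitrogen gives a 250-fold higher number from compound 2 to compound 3 (2.39 log units; beyond the scatter) and so shows that inhibition depends heavily on the group held at this position. The earlier compounds shown here carried only branched chains here and gave no single-change reading of this site. Nothing available accounts for the size of this step. The compounds shown leave open where between methyl and tert-butyl the loss sets in, and whether an ethyl or isopropyl group would keep inhibition closer to that of compound 2. They also leave open how a cyclopentyl group would fare at this position.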